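The source may report more compounds than this note shows. Statements on the series, on what has been measured and on what is new or still open speak of the compounds shown alone.

Measured compounds:
- compound 1 `CC1(C)[C@H]2CC[C@]1(C)N(Cc1cn(-c3ccccc3Cl)nn1)C(=O)C2`: 220 nM
- compound 2 `COc1ccccc1-n1cc(CN2C(=O)C[C@@H]3CC[C@@]2(C)C3(C)C)nn1`: 280 nM
- compound 3 `CC1(C)[C@H]2CC[C@]1(C)N(Cc1cn(-c3ccccc3)nn1)C(=O)C2`: 240 nM

All three share the core of compound 1 and differ only in the group carried on the aromatic nitrogen of the five-membered ring. In a functional assay on SGC-7901 cells (Homo sapiens) for inhibition, read by MTT assay, with a stated time of 24 h (a higher number here means a weaker inhibitor, a lower number a stronger inhibitor), compound 2 gives the highest of the three numbers, but the steps of a 1.2-fold lower number from compound 2 to compound 3 (0.07 log units; within the scatter) and a 1.3-fold higher number from compound 1 to compound 2 (0.10 log units; within the scatter) both fall within the scatter, so no order among the three compounds can be read from these values.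

Compound 4 `COc1ccc(-n2cc(CN3C(=O)C[C@@H]4CC[C@@]3(C)C4(C)C)nn2)cc1` is the next compound in the series. Relative to compound 2 the change is 4-methoxyphenyl in place of 2-methoxyphenyl on an aromatic nitrogen. Among the compounds with values here, every measured step so far alters only the substitution of the aromatic ring on that nitrogen, and each was small: a 1.3-fold higher number from compound 1 to compound 2 (0.10 log units; within the scatter), a 1.1-fold higher number from compound 1 to compound 3 (0.04 log units; within the scatter) and a 1.2-fold lower number from compound 2 to compound 3 (0.07 log units; within the scatter) all lie within the scatter. Moving the methoxy group within that ring is a change of the same kind, and nothing among the measured compounds suggests a response beyond the scatter. The step expected in this assay is therefore a 1.0-fold lower number from compound 2 to compound 4 (0.02 log units; within the scatter), with no clear direction.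

On this basis compound 4 is estimated at 270 nM, with a likely range from 130 nM to 560 nM.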

Compound 4, half-maximal inhibitory concentration: 480 nM
The estimate for compound 4 lay 1.8-fold (0.25 log units) below the measured number; the measured number falls inside the stated range.
By their numbers in this assay, from the lowest: compounds 1, 3, 2 and 4 (each within the scatter of the next, the first and the last beyond it).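

In this assay the methoxy group on the ring carried by the aromatic nitrogen gives, on moving to form 4-methoxyphenyl, a 1.7-fold higher number from compound 2 to compound 4 (0.23 log units; within the scatter), and the same group in place of hydrogen gives a 2.0-fold higher number from compound 3 to compound 4 (0.30 log units; within the scatter), so neither step separates compound 4 from its closest neighbours, although both are larger than the steps among the first three compounds. The substitution of this ring is nonetheless not entirely without consequence: 4-methoxyphenyl in place of 2-chlorophenyl gives a 2.2-fold higher number from compound 1 to compound 4 (0.34 log units; beyond the scatter), a modest step and the only one in the series beyond the scatter, resting on this one pair, with compound 2 and compound 3 within the scatter of both ends. Nothing available explains this difference.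

From the compounds shown here alone, how far this sensitivity extends remains open, since all four compounds carry a neutral phenyl ring with at most a single chloro or methoxy group. An amine or a carboxylic acid on that ring, or a longer alkyl chain in its place, would show whether larger steps are possible at this position.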